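The source may hold more compounds than are shown below. What is called first, only, known or untested is meant among the compounds shown, and "the series" means these compounds.

Working notes on the series in a functional assay for antagonist activity at transient receptor potential cation channel subfamily V member 1 (Homo sapiens), read by FLIPR and calcium flux; a higher number here means a weaker inhibitor, a lower number a stronger inhibitor.

Of the compounds shown here, three sharing one core have been measured so far. Compound 1 `Cc1cccc(N2CCC(C(=O)Nc3ccc4c(c3)NC(=O)CO4)CC2)c1` gives 490 nM. Compound 2 `O=C1COc2ccc(NC(=O)C3CCN(c4ccccc4Br)CC3)cc2N1` gives 160 nM. Compound 3 `Cc1cccc(N2CCC(C(=O)Nc3ccc4c(c3)NC(=O)CO4)CC2)c1C` gives 60 nM, the lowest of the three numbers, with compound 2 nearest and compound 1 furthest. The step of a 3.1-fold lower number from compound 1 to compound 2 (0.49 log units; beyond the scatter) and the step of a 2.7-fold lower number from compound 2 to compound 3 (0.43 log units; beyond the scatter) are both modest, while the step of an 8.2-fold lower number from compound 1 to compound 3 (0.91 log units; beyond the scatter) is the largest seen.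

Compound 4 `Cc1c(Cl)cccc1N1CCC(C(=O)Nc2ccc3c(c2)NC(=O)CO3)CC1` is not yet measured. It differs from compound 3 by chloro in place of methyl on an aromatic carbon. Among the measured compounds shown here, no measured pair tests a chloro against a methyl on that aromatic ring, so only indirect bearings exist: the step of a 3.1-fold lower number from compound 1 to compound 2 (0.49 log units; beyond the scatter) shows a halogen on the aryl ring giving a lower number than a methyl, and the step of a 2.7-fold lower number from compound 2 to compound 3 (0.43 log units; beyond the scatter) shows that two methyls gave a lower number still. On that footing the swap of one methyl for chloro in compound 4 is expected to move this assay little, with the step of no change at the digits printed from compound 3 to compound 4 (within the scatter) estimated to stay within the scatter. Compound 4 is therefore estimated at 60 nM, with a range of 25 nM to 150 nM.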

Compound 4, half-maximal inhibitory concentration: 100 nM
Estimate against measurement, compound 4: 1.7-fold (0.22 log units) below; the measured number falls inside the stated range.
By their numbers in this assay, from the lowest: compounds 3, 4 and 2 (each within the scatter of the next, the first and the last beyond it); then compound 1.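

In this assay, among the compounds shown here, chloro in place of methyl on an aromatic carbon, ortho to a methyl group, gives a 1.7-fold higher number from compound 3 to compound 4 (0.22 log units; within the scatter), the first direct reading of this change, and it does not separate the 3-chloro-2-methylphenyl group from the 2,3-dimethylphenyl group. The further step, a 1.6-fold lower number from compound 2 to compound 4 (0.20 log units; within the scatter), also leaves compound 4 unresolved from the 2-bromophenyl group, even though compound 3 and compound 2 are separated beyond the scatter, while a 4.9-fold lower number from compound 1 to compound 4 (0.69 log units; beyond the scatter) shows that the 3-chloro-2-methylphenyl group, like the 2,3-dimethylphenyl group, stands clear of the 3-methylphenyl group. No measurement available here gives a reason for any of these steps.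

The compounds shown leave open how far this carbon accepts other groups, such as methoxy, trifluoromethyl, nitrile or an amine, since only methyl and chloro have been read there, both alongside the same neighbouring methyl. They also leave open what the neighbouring methyl contributes when chloro is present, a question that a 3-chlorophenyl or 2,3-dichlorophenyl group would address directly.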